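Removal of the amino-acid arm from the quinone core

This account rests on a few compounds, and the source may have more. Where it says the series, first, only, none or still open, it means among the compounds named here.

Compound 1 `C[C@H](NC1=CC(=O)C=C(C(C)(C)C)C1=O)C(=O)O` gives 89100 nM in a functional assay on HeLa cells (Homo sapiens) for cytotoxicity, read by MTT assay, with a stated time of 72 h; on this read-out higher numbers stand for weaker inhibition and lower numbers for stronger inhibition. Among the three measured compounds it holds the highest number, though its nearest neighbour, compound 2 `CSCC[C@H](NC1=CC(=O)C=C(C(C)(C)C)C1=O)C(=O)O` with 77400 nM, and its furthest, compound 3 `CC(C)C[C@H](NC1=CC(=O)C=C(C(C)(C)C)C1=O)C(=O)O` with 57200 nM, both lie within the scatter of it: the step of a 1.2-fold lower number from compound 1 to compound 2 (0.06 log units; within the scatter), the step of a 1.6-fold lower number from compound 1 to compound 3 (0.19 log units; within the scatter) and the step of a 1.4-fold lower number from compound 2 to compound 3 (0.13 log units; within the scatter) are all too small to read as change.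

Compound 4 `CC(C)(C)C1=CC(=O)C=CC1=O` differs from compound 1 by hydrogen in place of (1-carboxyethyl)amino on a double-bonded ring carbon. For the measured compounds named here, none of the measured steps touches this place: each swaps the substituent on the saturated chain carbon while keeping the (1-carboxyethyl)amino arm itself. Those steps, all within the scatter, show that varying the arm does little, but they say nothing about removing it. Going by the values given here, with no bearing step in hand, the expectation for compound 4 is kept near compound 1 with wide bounds, leaning toward a lower number, as a 3.0-fold lower number from compound 1 to compound 4 (0.47 log units; beyond the scatter). Compound 4 is therefore expected at 30000 nM, within 8000 nM to 120000 nM.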

Compound 4, half-maximal inhibitory concentration: 44100 nM
The estimate for compound 4 lay 1.5-fold (0.17 log units) below the measured number, and the stated range covers the measured number.
By their numbers in this assay, from the lowest: compounds 4, 3, 2 and 1 (each within the scatter of the next, the first and the last beyond it).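

Hydrogen in place of (1-carboxyethyl)amino on the double-bonded ring carbon is the only change shown that leaves the scatter: in this assay it gives a 2.0-fold lower number from compound 1 to compound 4 (0.31 log units; beyond the scatter) and the number falls rather than rises. The arm is therefore not required for the cytotoxicity seen on this read-out, and its presence in compound 1 goes with a modestly higher number, whereas swaps on its saturated chain carbon did not separate the compounds. No measurement at hand accounts for this step.

From the compounds shown here alone, it remains open whether a simple amine, such as methylamino, at this ring carbon would track compound 1 or compound 4, which would separate the nitrogen from the carboxylic acid. A methyl ester of the acid in the arm of compound 1 would test the carboxylic acid alone.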